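The source may report more compounds than this note shows. Statements on the series, on what has been measured and on what is new or still open speak of the compounds shown alone.

Measured so far in a functional assay on NUGC-3 cells (Homo sapiens) for antiproliferative activity, read by sulforhodamine B assay; on this read-out higher numbers stand for weaker inhibition of growth and lower numbers for stronger inhibition of growth:

compound 1 `CC1(C)CC(=O)c2s/c(=N/c3ccc(Cl)cc3)oc2C1` gives 2940 nM
compound 2 `CC1CC(=O)c2s/c(=N/c3ccc(Cl)cc3)oc2C1` gives 15900 nM

Among the compounds with values here, on these two numbers compound 1 stands lowest; its nearest neighbour is compound 2, and the only measured step, a 5.4-fold higher number from compound 1 to compound 2 (0.73 log units; beyond the scatter), is hydrogen in place of methyl on a saturated ring carbon. That step concerns the saturated part of the shared core and not the aryl substituent.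

Compound 3 `CC1(C)CC(=O)c2s/c(=N/c3ccc(F)cc3)oc2C1` keeps the dimethyl-bearing core of compound 1 and differs from it in one place only: fluoro in place of chloro on an aromatic carbon. Within the data shown here, no measured pair in this set exchanges one halogen for another on that ring, so the step from compound 1 to compound 2 does not bear on the change directly and gives no guide to its size or direction; the dimethyl core shared by compound 1 and compound 3 is the only fixed point. Among the measured compounds shown here, with no precedent, the expectation for this assay is a step of uncertain sign, most likely small, with the wider margin allowed towards weaker inhibition. Compound 3 is therefore estimated at 5000 nM, range 1500 nM to 17000 nM, which means an expected step of a 1.7-fold higher number from compound 1 to compound 3 (0.23 log units; within the scatter).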

Compound 3, concentration for 50% growth inhibition: 1080 nM
Estimate against measurement, compound 3: 4.6-fold (0.67 log units) above; measured number outside the range, below it.
By their numbers in this assay, from the lowest: compound 3; then compound 1; then compound 2.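

In this assay the aromatic carbon para to a large group proves sensitive to the identity of the halogen: fluoro in place of chloro gives a 2.7-fold lower number from compound 1 to compound 3 (0.43 log units; beyond the scatter) and moves the series towards stronger inhibition of growth. This makes the aromatic substituent a second place where a single exchange carries a step beyond the scatter, alongside the saturated ring carbon of a 5.4-fold higher number from compound 1 to compound 2 (0.73 log units; beyond the scatter) and on a part of the molecule that step left untouched. The gain is read on the dimethyl-bearing core alone, as one pair, and no measurement at hand speaks to what lies behind it.

As far as these compounds go, whether fluoro in place of chloro gives a step of like size and direction on the core of compound 2, with hydrogen in place of methyl on the saturated ring carbon, remains open. Also open is how the same aromatic position responds to hydrogen, to bromo, or to groups of another kind such as methoxy, nitrile or an amine, so the compounds shown do not yet define a trend at this position.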